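The source may hold more compounds than are shown below. What is called first, only, known or untested is meant among the compounds shown, and "the series" means these compounds.

Compound 3, `O=C(O)c1cc(OC2CC2)c2nc(N3C[C@@H]4C[C@H]3C[C@H]4OCc3c(C4CC4)nnn3-c3c(Cl)cccc3Cl)sc2c1`, is one of three compounds that share the same bridged bicyclic amine and the same dichlorophenyl-substituted five-membered heteroaromatic ring, and all three were tested in an assay on HEK293T cells for agonist activity at Bile acid receptor (Homo sapiens); on this read-out higher numbers stand for larger maximal responses and lower numbers for smaller maximal responses. Compound 1, `O=C(NS(=O)(=O)C1CCOCC1)c1ccc(N2C[C@@H]3C[C@H]2C[C@H]3OCc2c(C3CC3)cnn2-c2c(Cl)cccc2Cl)cc1`, gives 116% in this assay. Compound 2, `O=C(O)c1cc(OC2CC2)c2nc(N3C[C@@H]4C[C@H]3C[C@H]4OCc3c(C4CC4)cnn3-c3c(Cl)cccc3Cl)sc2c1`, carries the same fused bicyclic carboxylic acid as compound 3; in this assay compound 2 gives 116%. Compound 3 itself gives 116% in this assay, so it stands level with compound 1 and with compound 2 at the digits shown, and none of the three is set apart from the others by more than the usual scatter.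

Compound 4, `O=C(O)c1cc(C2CCOCC2)c2nc(N3C[C@@H]4C[C@H]3C[C@H]4OCc3c(C4CC4)nnn3-c3c(Cl)cccc3Cl)sc2c1`, is the next compound in this series, and it differs from compound 3 in a single place: oxan-4-yl in place of cyclopropyloxy on an aromatic carbon. Going by the values given here, no step between two measured compounds describes this kind of exchange, so nothing measured tells how the maximal response answers to it. Since compound 1, compound 2 and compound 3 all sit at the same level in this assay despite their differences elsewhere, the expectation is that the maximal response of compound 4 stays at that level, with the step of a number 4 percentage points lower from compound 3 to compound 4 (within the scatter) expected to fall within the scatter. Compound 4 is therefore estimated at 112% in this assay, within a range from 95% to 130%.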

Compound 4, largest response reached (Emax), in percent of the reference or control that the assay uses: 116%
For compound 4 the middle estimate is 4 percentage points below the measured one; the measured number falls inside the stated range.
By their numbers in this assay, from the lowest: compounds 1, 2, 3 and 4 (each within the scatter of the next).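

The exchange of cyclopropyloxy for oxan-4-yl on this aromatic carbon, meta to the carboxy group, gives no change at the digits printed from compound 3 to compound 4 (within the scatter) in this assay. This is the first step shown at this position, and it shows that the maximal response does not separate a group of four heavy atoms with a three-membered carbon ring from one of six heavy atoms with a six-membered ring holding one hetero atom. Nothing available accounts for this result.

From the compounds shown here alone, whether an amine, a hydroxyl group or a longer alkyl chain on the same aromatic carbon would also leave the maximal response within the scatter remains open, since the two groups compared here each carry one hydrogen-bond acceptor, no hydrogen-bond donor and no net charge. The read-out shown reports only the largest response reached, so the concentration needed to reach that response for compound 3 and compound 4 also remains open.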